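The compounds below may be only part of what the source reports. "The series", "measured", "known", "first", "only" and "open" are said of these compounds alone.

Measured compounds: compound 1 `CCCSc1nc(N/N=C/c2cccnc2)c2nnn(Cc3ccccc3)c2n1` gives > 64000 nM in a functional assay on ECa-109 cells (Homo sapiens) for antiproliferative activity, read by MTT assay, with a stated time of 72 h (on this read-out lower numbers stand for stronger inhibition and higher numbers for weaker inhibition), which is a limit of the assay rather than a number. Compound 2 `CCCSc1nc(N/N=C/c2ccc(N(C)C)cc2)c2nnn(Cc3ccccc3)c2n1` gives 20000 nM in this assay.

Among the measured compounds shown here, compound 2 thus holds the only numerical value shown; the other value is a limit (the limit of > 64000 nM in this assay, at which 1 of the 2 values shown sits). For the measured compounds named here, the step of an at least 3.2-fold lower number from compound 1 to compound 2 (0.50 log units; beyond the scatter) is the one measured step, and it went with the exchange of pyridin-3-yl for 4-(dimethylamino)phenyl on the carbon double-bonded to nitrogen.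

Compound 3 `CCCSc1nc(N/N=C/c2ccc3ccccc3c2)c2nnn(Cc3ccccc3)c2n1` is not yet measured. It differs from compound 2 by naphthalen-2-yl in place of 4-(dimethylamino)phenyl on a carbon with a double bond to nitrogen. Going by the values given here, no measured step concerns naphthalen-2-yl at this position, so the one measured step gives only weak guidance. Compound 3 is therefore expected to sit near compound 2, with a step of a 1.3-fold higher number from compound 2 to compound 3 (0.10 log units; within the scatter) that is expected to remain within the scatter. The estimate for compound 3 in this assay is 25000 nM, within 8000 nM to 80000 nM.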

Compound 3, half-maximal inhibitory concentration: > 64000 nM
Compound 3 was reported as a limit; the forecaster's own chance of this, stated with the estimate: 35%; at least 2.5-fold (0.40 log units) between middle value and limit.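

The exchange of 4-(dimethylamino)phenyl for naphthalen-2-yl on the carbon with a double bond to nitrogen gave an at least 3.2-fold higher number from compound 2 to compound 3 (0.50 log units; beyond the scatter) in this assay. Together with the earlier step, this shows that the number of compound 2 was lost both with pyridin-3-yl and with a group of carbon rings only, so a larger aromatic group alone did not keep it. Compound 1 and compound 3 both stand at a limit, and the step between them cannot be read: the limit of > 64000 nM in this assay, at which 2 of the 3 values shown sit.

The compounds shown leave open whether the number of compound 2 goes with the dimethylamino group itself or with the phenyl ring that carries it. A plain phenyl, or a phenyl bearing a primary amine or a methoxy group, at this place would bear on that question.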